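Ether-to-ester step on the shared core: compound 3 to compound 4

The source may report more compounds than this note shows. Statements on the series, on what has been measured and on what is new or still open speak of the compounds shown alone.

Measured in a functional assay on DU-145 cells (Homo sapiens) for cytotoxicity, read by MTT assay; a lower number here means a stronger inhibitor, a higher number a weaker inhibitor:
- compound 1 `CC(C)=CC[C@@H](OC(=O)CCO)C1=CC(=O)c2c(O)ccc(O)c2C1=O` gives 55300 nM
- compound 2 `CCC(O)CO[C@H](CC=C(C)C)C1=CC(=O)c2c(O)ccc(O)c2C1=O` gives 16400 nM
- compound 3 `CC(C)=CC[C@@H](OCCO)C1=CC(=O)c2c(O)ccc(O)c2C1=O` gives 9900 nM

Compound 3 is not separated from compound 2 (a 1.7-fold lower number from compound 2 to compound 3 (0.22 log units; within the scatter)), while compound 1 stands clearly higher (a 5.6-fold lower number from compound 1 to compound 3 (0.75 log units; beyond the scatter)). Compound 4 `CC(C)=CC[C@@H](OC(=O)C1CCCCO1)C1=CC(=O)c2c(O)ccc(O)c2C1=O` carries (oxan-2-yl)carbonyl in place of 2-hydroxyethyl on an oxygen on a saturated carbon. Two modest steps bear on this, both away from the carbonyl-linked compound 1: a 5.6-fold lower number from compound 1 to compound 3 (0.75 log units; beyond the scatter) and a 3.4-fold lower number from compound 1 to compound 2 (0.53 log units; beyond the scatter). Read in reverse, they point to a modest rise in this assay, although no ring-bearing group has been measured. The expected step is a 2.5-fold higher number from compound 3 to compound 4 (0.40 log units; beyond the scatter). The estimate for compound 4 is 25000 nM, with an expected range of 7000 nM to 70000 nM.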

Compound 4, half-maximal inhibitory concentration: 24700 nM
The estimate for compound 4 lay 1.0-fold (0.01 log units) above the measured number; the range from low to high includes it.
By their numbers in this assay, from the lowest: compounds 3, 2 and 4 (each within the scatter of the next, the first and the last beyond it); then compound 1.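

In this assay, a ring-bearing group on this oxygen on a saturated carbon is tolerated within a modest range: (oxan-2-yl)carbonyl raises the number relative to the 2-hydroxyethyl ether (a 2.5-fold higher number from compound 3 to compound 4 (0.40 log units; beyond the scatter)), yet lowers it relative to the open-chain ester (a 2.2-fold lower number from compound 1 to compound 4 (0.35 log units; beyond the scatter)). The carbonyl link therefore does not by itself set the number at the level of compound 1, and compound 4 is not separated from the 2-hydroxybutyl ether (a 1.5-fold higher number from compound 2 to compound 4 (0.18 log units; within the scatter)). No measurement shown accounts for these steps.

Still open, as far as these compounds go, is how an amine or a carboxylic acid on this oxygen would read. Also open, from the compounds shown here alone, is whether oxan-2-yl attached without the carbonyl would match the ethers.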